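From Compound 3 to an Unmeasured Ethenyl Analogue

The source may hold more compounds than are shown below. What is called first, only, known or untested is meant among the compounds shown, and "the series" means these compounds.

In a functional assay on DU-145 cells (Homo sapiens) for cytotoxicity, read by MTT assay, with a stated time of 48 h (on this read-out lower numbers stand for stronger inhibition and higher numbers for weaker inhibition), three related compounds have been measured so far. Compound 1 `COc1ccc(/C=C/c2cc(OC)c(OC)c(OC)c2-c2ccc(OC)cc2)cc1` gives 34000 nM, and compound 2 `COc1ccc(/C=C/c2cc(OC)c(OC)c(OC)c2-c2ccc(F)c(F)c2)cc1` gives 7500 nM. Compound 3 `COc1cc(/C=C/c2ccccc2)c(-c2ccccc2)c(OC)c1OC` gives 82000 nM, the highest of the three numbers and beyond the scatter from both of the others, which makes it the weakest of this small set.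

The next compound, compound 4 `C=C(c1ccc(C)cc1)c1cc(OC)c(OC)c(OC)c1-c1ccccc1`, differs from compound 3 in one place: 1-(4-methylphenyl)ethenyl in place of 2-phenylethenyl on an aromatic carbon. Here, 1-(4-methylphenyl)ethenyl stands in place of 2-phenylethenyl on an aromatic carbon, ortho to a phenyl group.

For the measured compounds named here, only one measured step is available, and it offers indirect guidance at best. The modest step of a 4.5-fold lower number from compound 1 to compound 2 (0.66 log units; beyond the scatter) comes from 3,4-difluorophenyl in place of 4-methoxyphenyl, a different replacement from the one made here. Going by the values given here, no measured step involves the ethenyl group, so the size of this change cannot be read directly from the data. Among the compounds with values here, with only that modest step as a guide, no shift beyond the scatter is expected in this assay, though a slightly lower number seems the more likely direction. The estimated change is a 1.6-fold lower number from compound 3 to compound 4 (0.21 log units; within the scatter). Compound 4 is expected at 50000 nM, with an estimated range from 15000 nM to 130000 nM.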

Compound 4, half-maximal inhibitory concentration: 28000 nM
Compound 4: the middle estimate sits 1.8-fold (0.25 log units) above what was measured, and the stated range covers the measured number.
By their numbers in this assay, from the lowest: compound 2; then compounds 4 and 1 (each within the scatter of the next); then compound 3.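

Moving from 2-phenylethenyl to 1-(4-methylphenyl)ethenyl on the aromatic carbon ortho to a phenyl group gives a 2.9-fold lower number from compound 3 to compound 4 (0.47 log units; beyond the scatter) in this assay, so this position responds to a change in the ethenyl group. For the compounds shown here, the only earlier step, a 4.5-fold lower number from compound 1 to compound 2 (0.66 log units; beyond the scatter), concerned the 4-methoxyphenyl group and said nothing about this site. Both groups keep one six-membered aromatic ring and one double bond outside aromatic rings, and nothing shown gives a reason for the shift.

The step joins two alterations, the point at which the aromatic ring sits on the ethenyl group and the added 4-methyl group, and a plain 1-phenylethenyl group would be needed to tell their shares apart. On these data alone, how an amine or a carboxylic acid in place of that methyl group would read in this assay, and whether the same ethenyl change would carry over to the 3,4-difluorophenyl series of compound 2, remains open.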